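Trifluoromethyl placement in a hydroxyphenyl series

The compounds below may be only part of what the source reports. "The series", "measured", "known", "first", "only" and "open" are said of these compounds alone.

Measured compounds:
compound 1, `Oc1ccc(-c2cc(-c3ccccc3C(F)(F)F)cc(-c3ccccc3O)n2)cc1`: 16500 nM
compound 2, `Oc1ccc(-c2cc(-c3cccc(C(F)(F)F)c3)cc(-c3ccccc3O)n2)cc1`: > 50000 nM (a limit of the assay, not a number)
compound 3, `Oc1cccc(-c2cc(-c3ccccc3C(F)(F)F)cc(-c3cccc(O)c3)n2)c1`: 15200 nM

All numbers come from a functional assay on HeLa cells (Homo sapiens) for inhibition; a higher number here means a weaker inhibitor, a lower number a stronger inhibitor. Compound 1 carries a 2-hydroxyphenyl group and a 4-hydroxyphenyl group on the shared core and gives 16500 nM. Compound 2 reaches only a limit of the assay, > 50000 nM, so its value is a limit and not a number; this is the limit of > 50000 nM in this assay, at which 1 of the 3 values shown sits. The step between them is an at least 3.0-fold higher number from compound 1 to compound 2 (0.48 log units; beyond the scatter), made by 3-(trifluoromethyl)phenyl in place of 2-(trifluoromethyl)phenyl on an aromatic carbon.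

Compound 3 carries two 3-hydroxyphenyl groups and gives 15200 nM; set beside compound 1, the two numbers lie within the usual scatter, so no order between them is claimed. How the core of compound 3 differs from that of compound 1 is not broken down here.

Compound 4, `Oc1cccc(-c2cc(-c3cccc(C(F)(F)F)c3)cc(-c3cccc(O)c3)n2)c1`, is not yet measured. It arises from compound 3 by 3-(trifluoromethyl)phenyl in place of 2-(trifluoromethyl)phenyl on an aromatic carbon, the same kind of change as from compound 1 to compound 2, though the place differs: there the site was meta to a 2-hydroxyphenyl group and meta to a 4-hydroxyphenyl group, here it is meta to two 3-hydroxyphenyl groups. Among the compounds with values here, on the single earlier instance, an at least 3.0-fold higher number from compound 1 to compound 2 (0.48 log units; beyond the scatter), a step of a 3.3-fold higher number from compound 3 to compound 4 (0.52 log units; beyond the scatter) is expected. Compound 4 is therefore estimated at 50000 nM, between 20000 nM and 150000 nM, with a real chance that only a limit is reported.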

Compound 4, half-maximal inhibitory concentration: 12700 nM
Compound 4: the middle estimate sits 3.9-fold (0.60 log units) above what was measured; measured number below the stated range.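

In this assay, the exchange of 2-(trifluoromethyl)phenyl for 3-(trifluoromethyl)phenyl does not carry the same result from one core to the other: the same change on two cores in this assay, an at least 3.0-fold higher number (0.48 log units; beyond the scatter) from compound 1 to compound 2 and a 1.2-fold lower number (0.08 log units; within the scatter) from compound 3 to compound 4, at least 3.6-fold (0.55 log units) apart, beyond the scatter of two such steps

On the core of compound 3, the exchange gives a 1.2-fold lower number from compound 3 to compound 4 (0.08 log units; within the scatter), so no effect that can be told from the scatter is seen on this core. From the compounds shown here alone, compound 2 stands at > 50000 nM, a limit of the assay and not a number, so the full size of the earlier step stays unknown, and the two cores neither give a rule for a third core nor show which feature of the cores decides the outcome.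

The compounds shown leave open whether the split between the cores also holds when a nitrile, an amine or a carboxylic acid takes the place of the trifluoromethyl group on this phenyl ring. Going by these compounds, it also remains open how much of the split belongs to each hydroxyphenyl group, and whether a methoxy group in place of a hydroxy group would change it.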